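From 3-chlorophenyl to 4-fluorophenyl on a shared core

The compounds below may be only part of what the source reports. "The series", "measured", "known", "first", "only" and "open" are said of these compounds alone.

Compound 1 (`COc1nc(-c2cccc(Cl)c2)ccc1[C@@H](c1ccccc1)[C@@](O)(CCN(C)C)c1cccc2ccccc12`) offers no number to start from. In a toxicity assay on HeLa cells (Homo sapiens) for cytotoxicity (a lower number here means that less compound is tolerated, a higher number that more compound is tolerated), compound 1 gives "nd" (no result reported). Compound 2 (`COc1nc(-c2ccccc2F)ccc1[C@@H](c1ccccc1)[C@@](O)(CCN(C)C)c1cccc2ccccc12`), built on the same core, likewise gives "nd" (no result reported). The only reported result belongs to compound 3 (`COc1nc(-c2ccsc2)ccc1[C@@H](c1ccccc1)[C@@](O)(CCN(C)C)c1cccc2ccccc12`). Compound 3 reads > 64 ug/mL, which is a limit of the assay and not a number. The evidence therefore comes down to a single entry: the limit of > 64 ug/mL in this assay, at which 1 of the 3 values shown sits.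

Compound 4 (`COc1nc(-c2ccc(F)cc2)ccc1[C@@H](c1ccccc1)[C@@](O)(CCN(C)C)c1cccc2ccccc12`) has not yet been measured. The structural change is 4-fluorophenyl in place of 3-chlorophenyl on an aromatic carbon, next to the ring nitrogen of a six-membered aromatic ring with 1 nitrogen. For the measured compounds named here, no pair of measured compounds shows what a replacement at this place does, so the size of the step cannot be read from the data. No step beyond the scatter is expected in this assay, and no direction is assumed. Going by the values given here, the one guide is compound 3, whose limit of > 64 ug/mL suggests that a reading near that limit is likely. The estimated value for compound 4 is 64 ug/mL, with an expected range from 25 ug/mL to 100 ug/mL.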

Compound 4, half-maximal cytotoxic concentration: > 64 ug/mL
Compound 4: a limit, no number; the forecaster's own chance of this, stated with the estimate: 70%; the middle value sits exactly at the limit.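

In this assay compound 4 gives > 64 ug/mL, which is a limit of the assay and not a number. For the compounds shown here, compound 3 also reads as a limit, so no step between compound 3 and compound 4 can be read. The compounds shown leave open what the half-maximal cytotoxic concentration of any of them actually is.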